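Swapping Chloro for Fluoro on a Short Acrylamide

This account rests on a few compounds, and the source may have more. Where it says the series, first, only, none or still open, it means among the compounds named here.

Measured so far:
- compound 1, `O=C(/C=C/C(F)(F)F)Nc1ccccc1`: 0.267 h
- compound 2, `C=C(Cl)C(=O)Nc1ccccc1`: 0.05 h
- compound 3, `O=C(/C=C/CN1CCCC1)Nc1ccccc1`: 2.7 h

Three compounds share one core, a simple anilide, and differ only in the short unsaturated chain attached to the carbonyl. In an ADME assay for pharmacokinetics, read by LC-MS, in phosphate buffer, with a stated time of 120 min, at pH 7.4, tested at 1 uM, in the presence of a further agent that is not named here (a higher number here means that the compound lasts longer, a lower number that the compound disappears faster), compound 1 gives 0.267 h, while compound 3 gives 2.7 h. Compound 2, with its chloro group, gives 0.05 h; this is the lowest of the three numbers, and its gap to compound 1 as well as its gap to compound 3 lie beyond the usual scatter, so compound 2 disappears fastest of the set by a clear margin.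

The next compound, compound 4, `C=C(F)C(=O)Nc1ccccc1`, is made from compound 2 by one change: fluoro in place of chloro on a double-bonded chain carbon bound to a carbonyl carbon.

Among the measured compounds shown here, no measured pair in this set shows this exact change, so there is no direct precedent for the size of the step. Nothing in the three measured values speaks for a change that would exceed the scatter in either direction, so a modest or negligible shift in this assay is the more cautious expectation. Compound 4 is therefore expected to give about 0.12 h, within a range of 0.04 h to 0.4 h, which corresponds to an estimated step of a 2.4-fold higher number from compound 2 to compound 4 (0.38 log units; beyond the scatter).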

Compound 4, half-life: > 8.53 h
Compound 4 was reported as a limit; the forecaster's own chance of this, stated with the estimate: 5%; at least 71-fold (1.85 log units) between middle value and limit.
By their numbers in this assay, from the lowest: compound 2; then compound 1; then compound 3. At a limit, above all of these: compound 4.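

The earlier compounds shown here differ from one another by their whole chain, so they could not show what one exchange at this place does on its own; in this assay, fluoro in place of chloro on a double-bonded chain carbon bound to a carbonyl carbon gives an at least 170-fold higher number from compound 2 to compound 4 (2.23 log units; beyond the scatter). This large step shows that the number in this assay can depend strongly on which of these two groups sits at this place, even with the rest of the structure unchanged. Compound 4 is reported only as a limit, > 8.53 h, so the full size of the step stays unknown: the limit of > 8.53 h in this assay, at which 1 of the 4 values shown sits.

From the compounds shown here alone, whether other groups at this place, such as bromo, methyl or nitrile, would stay nearer to compound 2 or to compound 4 remains open. So does whether the same swap would give a step of similar size on a longer chain or on a chain carrying an amine, and the compounds shown do not reveal why this exchange has so large an effect.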